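The source may report more compounds than this note shows. Statements on the series, on what has been measured and on what is new or still open speak of the compounds shown alone.

Measured compounds:
compound 1, `CC(=O)c1cc(-c2ccc(F)cc2)cc2cc(-c3ccccc3)[nH]c12`, 73.8%
compound 2, `COc1ccc(-c2cc(C(C)=O)c3[nH]c(-c4ccccc4)cc3c2)cc1`, 49.5%

In a functional assay on MCF7 cells (Homo sapiens) for cytotoxicity, read by MTT assay, with a stated time of 2 days, tested at 10 uM (on this read-out higher numbers stand for a weaker effect at the one concentration tested and lower numbers for a stronger effect), compound 1 gives 73.8%, the higher of the two numbers at hand, while compound 2 gives 49.5%. Among the compounds with values here, the one measured step, a number 24.3 percentage points lower from compound 1 to compound 2 (beyond the scatter), swaps methoxy in place of fluoro on an aromatic carbon and is beyond the scatter, though modest.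

Compound 3, `CC(=O)c1cc(-c2ccc(F)cc2)cc2cc(-c3ccc(F)cc3)[nH]c12`, departs from compound 1 elsewhere: fluoro in place of hydrogen on an aromatic carbon. Within the data shown here, no measured step touches this ring, so the step from compound 1 to compound 2 offers only a sense of scale, not a direction. With the shared core kept and a single fluorine added, the expectation is for no step beyond the scatter, written as a number 3.8 percentage points lower from compound 1 to compound 3 (within the scatter). Compound 3 is therefore estimated at 70% in this assay, with a range from 50% to 90%.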

Compound 3, a percentage reported as activity, at one concentration (the size of the read-out at that concentration, not a potency): 90.6%
Compound 3: the middle estimate sits 20.6 percentage points below what was measured, outside the stated range (above it).
By their numbers in this assay, from the lowest: compound 2; then compound 1; then compound 3.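

In this assay the change from phenyl to 4-fluorophenyl gives a number 16.8 percentage points higher from compound 1 to compound 3 (beyond the scatter) and so moves the read-out towards a weaker effect, which shows that this ring, untouched by the earlier step, is not indifferent to substitution para to a large group. The earlier step of a number 24.3 percentage points lower from compound 1 to compound 2 (beyond the scatter) lay at a different place on the shared core and went towards a stronger effect, so both places now move the number, in opposite directions. Nothing at hand accounts for the weaker effect of compound 3.

As far as these compounds go, whether this loss belongs to fluoro alone or to any group at this position stays open, since one substituent cannot settle it. Methoxy, a chlorine atom, an amine or a carboxylic acid on this ring could each answer that.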